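One Added Methoxy on a Weak Inhibitor

The compounds below may be only part of what the source reports. "The series", "measured", "known", "first", "only" and "open" are said of these compounds alone.

Only two results exist so far in a functional assay on RAW264.7 cells (Mus musculus) for inhibition, with stated times of 2 h and 24 h; a lower number here means a stronger inhibitor, a higher number a weaker inhibitor. Compound 1 (`COc1ccc([C@@H]2c3c(OC)cc(OC)cc3C(SCc3ccc(F)cc3)[C@H]2c2cc(OC)cc(OC)c2)cc1`) reads > 200000 nM, and this is a limit of the assay, not a number. Among the measured compounds shown here, compound 2 (`COc1cc(OC)cc([C@@H]2C(C(O)c3ccccc3)c3cc(OC)cc(OC)c3[C@H]2c2ccccc2)c1`) gives 21600 nM, the only true number available, so it cannot yet be ranked against another measured value.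

Compound 3 (`COc1ccc([C@@H]2c3c(OC)cc(OC)cc3C(C(O)c3ccccc3)[C@H]2c2cc(OC)cc(OC)c2)cc1`) differs from compound 2 in one place: methoxy in place of hydrogen on an aromatic carbon. Put simply, a phenyl becomes a 4-methoxyphenyl, with methoxy in place of hydrogen on an aromatic carbon, para to a large group.

For the measured compounds named here, no measured pair shows what this swap does in this assay, so the data give no direction for it. The best anchor is compound 2 at 21600 nM, and the expectation stays close to it, with no change beyond the scatter of repeated measurements. The expected step of a 1.1-fold lower number from compound 2 to compound 3 (0.03 log units; within the scatter) is therefore small, although this is an uncertain estimate resting on a single number. For compound 3 the estimated value is 20000 nM, within an expected range of 6000 nM to 80000 nM.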

Compound 3, half-maximal inhibitory concentration: > 200000 nM
Compound 3: no number, only a limit; the forecaster's own chance of this, stated with the estimate: 15%; at least 10-fold (1.00 log units) between middle value and limit.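

In this assay, among the compounds shown here, this is the first measured sign that the aromatic carbon para to a large group is sensitive to change: a phenyl becoming a 4-methoxyphenyl gives an at least 9.2-fold higher number from compound 2 to compound 3 (0.96 log units; beyond the scatter), and that step points towards weaker inhibition. Compound 3 reads > 200000 nM, which is a limit and not a number, so the step has a lower bound but no known full size. The step between compound 1 and compound 3 cannot be read, because both compounds sit at the same limit: the limit of > 200000 nM in this assay, at which 2 of the 3 values shown sit.

On these data alone, it remains open whether this loss is specific to methoxy or would follow from other replacements for hydrogen on the same ring carbon, such as a fluorine, a hydroxy group or an amine. For the compounds shown here, with compound 2 as the only compound giving a true number, it is also unclear how the hydroxy(phenyl)methyl and (4-fluorobenzyl)sulfanyl groups compare on the saturated ring carbon when the 4-methoxyphenyl is present.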